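The source may hold more compounds than are shown below. What is called first, only, known or untested is meant among the compounds shown, and "the series" means these compounds.

Measured compounds:
- compound 1 `COc1ccc(/C=C/C(=O)c2c(C)[n+]([O-])c3ccccc3[n+]2[O-])cc1`: in a functional assay on MOLT-4 cells (Homo sapiens) for inhibition, with a stated time of 3 days (a lower number here means a stronger inhibitor, a higher number a weaker inhibitor), compound 1 gives 25800 nM
- compound 2 `Cc1c(C(=O)/C=C/c2ccc(Cl)cc2)[n+]([O-])c2ccccc2[n+]1[O-]`: in this assay compound 2 gives 7750 nM
- compound 3 `Cc1c(C(=O)/C=C/c2ccc(Cl)c(Cl)c2)[n+]([O-])c2ccccc2[n+]1[O-]`: in this assay compound 3 gives 10100 nM

Compound 3 stands second highest of the three numbers in this assay; its nearest neighbour is compound 2, with a 1.3-fold higher number from compound 2 to compound 3 (0.12 log units; within the scatter), and its furthest is compound 1, with a 2.6-fold lower number from compound 1 to compound 3 (0.41 log units; beyond the scatter).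

Compound 4 `Cc1ccc(/C=C/C(=O)c2c(C)[n+]([O-])c3ccccc3[n+]2[O-])cc1` is not yet measured. Relative to compound 3 the change is 4-methylphenyl in place of 3,4-dichlorophenyl on a double-bonded chain carbon bound to a double-bonded chain carbon.

Within the data shown here, two measured steps touch the same position. The step from methoxy to chloro gave a 3.3-fold lower number from compound 1 to compound 2 (0.52 log units; beyond the scatter), and the step from 4-methoxyphenyl to 3,4-dichlorophenyl gave a 2.6-fold lower number from compound 1 to compound 3 (0.41 log units; beyond the scatter); both are modest. Adding the second chloro gave a 1.3-fold higher number from compound 2 to compound 3 (0.12 log units; within the scatter), which changes little. None of these steps involves a methyl group, so the direction for compound 4 rests on indirect evidence only: the chloro-bearing compounds sit lower than the methoxy-bearing compound 1, and a methyl group is neither. A step of modest size in this assay, toward a higher number than compound 3 or none beyond the scatter, is therefore expected, estimated as a 1.3-fold higher number from compound 3 to compound 4 (0.11 log units; within the scatter).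

The estimate for compound 4 in this assay is 13000 nM, with a range from 6000 nM to 30000 nM.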

Compound 4, half-maximal inhibitory concentration: 8400 nM
Estimate against measurement, compound 4: 1.5-fold (0.19 log units) above, within the range that was stated.
By their numbers in this assay, from the lowest: compounds 2, 4 and 3 (each within the scatter of the next); then compound 1.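

In this assay, methyl and chloro on the aromatic carbon cannot be told apart, with a 1.1-fold higher number from compound 2 to compound 4 (0.03 log units; within the scatter) in the comparison, and 4-methylphenyl and 3,4-dichlorophenyl on a double-bonded chain carbon bound to a double-bonded chain carbon also cannot be told apart, with a 1.2-fold lower number from compound 3 to compound 4 (0.08 log units; within the scatter) in the comparison. Methyl in place of methoxy gives a 3.1-fold lower number from compound 1 to compound 4 (0.49 log units; beyond the scatter) as its result, so the earlier gap between compound 1 and the chloro-bearing compounds does not require chloro: among the four compounds, compound 1 alone stands apart, and none of the others goes against this. Nothing available here bears on what separates compound 1 from the other three compounds.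

Open, on these data alone, is whether an amine, a carboxylic acid or a longer chain in place of methyl at this position would read with compound 1 or with compounds 2, 3 and 4. Also open, as far as these compounds go, is where an unsubstituted phenyl group would fall, and so whether methoxy raises the number or methyl and chloro lower it.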